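Replacing a methoxyphenyl with a difluorophenyl on a sulfone

The source may hold more compounds than are shown below. What is called first, only, known or untested is meant among the compounds shown, and "the series" means these compounds.

Measured compounds:
compound 1 `COc1cccc(-c2c(S(=O)(=O)c3cc(F)cc(F)c3)cnc3cc(F)ccc23)c1`: 1.81 mL/min
compound 2 `COc1cccc(S(=O)(=O)c2cnc3cc(F)ccc3c2-c2cccc(F)c2)c1`: 3.36 mL/min

Of the compounds shown here, two have been measured in an ADME assay on microsomes from liver (Homo sapiens) for metabolic stability, tested at 2.5 uM; on this read-out lower numbers stand for slow clearance and higher numbers for fast clearance. Compound 1 `COc1cccc(-c2c(S(=O)(=O)c3cc(F)cc(F)c3)cnc3cc(F)ccc23)c1` gives 1.81 mL/min in this assay, and compound 2 `COc1cccc(S(=O)(=O)c2cnc3cc(F)ccc3c2-c2cccc(F)c2)c1` gives 3.36 mL/min. Compound 2 has the highest of the two numbers, yet its nearest neighbour, compound 1, lies within the scatter of it, so the two values cannot be told apart with confidence.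

The next compound, compound 3 `O=S(=O)(c1cc(F)cc(F)c1)c1cnc2cc(F)ccc2c1-c1cccc(F)c1`, has not yet been measured in this assay. It differs from compound 2 in one place: 3,5-difluorophenyl in place of 3-methoxyphenyl on a sulfonyl sulfur. The aryl group on the core itself stays as it is in compound 2.

Within the data shown here, no measured pair shows what this particular change does, so the expected step has to be stated without a measured precedent. Compound 1, which also carries a 3,5-difluorophenyl on its sulfonyl sulfur, sits at 1.81 mL/min, a number that overlaps with compound 2 within the scatter. On that basis the expected step from compound 2 to compound 3 in this assay is a 1.5-fold lower number from compound 2 to compound 3 (0.16 log units; within the scatter), small and not clearly beyond the scatter, leaning if anything toward lower numbers. Compound 3 is therefore estimated at 2.3 mL/min, with a range from 1.1 mL/min to 4.6 mL/min.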

Compound 3, intrinsic clearance in a liver preparation (reported as CLH), per the amount of preparation that the assay uses: 0.06 mL/min
Beside the measured number, compound 3's estimate is 38-fold (1.58 log units) above it; measured number outside the range, below it.
By their numbers in this assay, from the lowest: compound 3; then compounds 1 and 2 (each within the scatter of the next).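

In this assay, 3,5-difluorophenyl in place of 3-methoxyphenyl on a sulfonyl sulfur gives a 56-fold lower number from compound 2 to compound 3 (1.75 log units; beyond the scatter), so this position can carry a large change in the read-out, which the earlier pair could not show because compounds 1 and 2 differ in more than one place. The 3,5-difluorophenyl on the sulfonyl sulfur is not enough on its own, as fluoro in place of methoxy on an aromatic carbon gives a 30-fold lower number from compound 1 to compound 3 (1.48 log units; beyond the scatter), and across these three compounds, the two that keep a methoxy group have the higher numbers, while compound 3, which has none, has the lowest. No supporting measurement bears on why either step is so large.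

The compounds shown leave open whether the steps follow the departure of the methoxy group or the arrival of fluorine, since each step makes both changes at once. A plain phenyl or a 3-ethoxyphenyl on the sulfonyl sulfur would help separate the two, and a 3-chlorophenyl on the core would test how far the step depends on fluorine itself.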